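Replacing Ethylsulfanyl with Cyclobutylmethoxy on a Shared Core

This account rests on a few compounds, and the source may have more. Where it says the series, first, only, none or still open, it means among the compounds named here.

Compound 1 `COC(=O)C1=C(C)NC(=O)NC1c1ccoc1` gives 8% in an assay on membranes from CHO cells for displacement of a labelled ligand from adenosine receptor A1 (Homo sapiens), read by scintillation counting, with a stated time of 60 min, tested at 1 uM; on this read-out higher numbers stand for more inhibition at the one concentration tested (going by the name of the read-out) and lower numbers for less inhibition.
Compound 2 `CCSC(=O)C1=C(C)NC(=O)NC1c1ccoc1` gives 3% in this assay.

Compound 2 stands beside compound 1 rather than apart from it: the step of a number 5 percentage points lower from compound 1 to compound 2 (within the scatter) lies within the scatter, so the two numbers cannot be told apart. Compound 3 `CC1=C(C(=O)OCC2CCC2)C(c2ccoc2)NC(=O)N1` differs from compound 2 by cyclobutylmethoxy in place of ethylsulfanyl on a carbonyl carbon. Among the measured compounds shown here, the one measured step, a number 5 percentage points lower from compound 1 to compound 2 (within the scatter), also altered the group on this carbonyl carbon and left the number essentially unmoved, so in this assay no step beyond the scatter is expected here either. Compound 3 is therefore expected to give 5%, in the range -5% to 15%. This means an expected step of a number 2 percentage points higher from compound 2 to compound 3 (within the scatter), within the scatter.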

Compound 3, a percentage reported as inhibition, at one concentration (the size of the read-out at that concentration, not a potency): 46%
Beside the measured number, compound 3's estimate is 41 percentage points below it; the measured number lies above the stated range.
By their numbers in this assay, from the lowest: compounds 2 and 1 (each within the scatter of the next); then compound 3.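

Set against ethylsulfanyl, cyclobutylmethoxy gives a number 43 percentage points higher from compound 2 to compound 3 (beyond the scatter), and set against methoxy, adding the cyclobutyl gives a number 38 percentage points higher from compound 1 to compound 3 (beyond the scatter). The flat result of the earlier pair therefore does not hold for every group on this carbonyl carbon: in this assay, the group placed here can change the inhibition seen at the one concentration tested. Nothing available explains this rise.

From the compounds shown here alone, it remains open whether the four-membered ring itself matters or whether the added carbons alone are enough. A longer open chain such as pentyloxy, or a cyclopentylmethoxy group, would help separate the two.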